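Moving the Fluorine on the Ketone-Bearing Ring

The source may report more compounds than this note shows. Statements on the series, on what has been measured and on what is new or still open speak of the compounds shown alone.

Measured so far in a functional assay on the whole organism (Ear) for inhibition, with Mus musculus as the target, with a stated time of 30 min, at a dose of 100 mg/kg by the intraperitoneal route; on this read-out lower numbers stand for less inhibition and higher numbers for more inhibition at the one dose given (going by the name of the read-out):
compound 1 `O=C(/C=C/c1ccc(/C=N/NC(=O)c2ccncc2)cc1)c1cccc(Br)c1` gives 14%
compound 2 `O=C(/C=C/c1ccc(/C=N/NC(=O)c2ccncc2)cc1)c1ccc(F)cc1` gives 51.1%
compound 3 `Cc1ccc(C(=O)/C=C/c2ccc(/C=N/NC(=N)N)cc2)cc1` gives 77.7%

Compound 2 stands second highest of the three, above compound 1 and below compound 3, and both gaps lie beyond the scatter. Compound 4 `O=C(N/N=C/c1ccc(/C=C/C(=O)c2ccccc2F)cc1)c1ccncc1` has not yet been measured; it differs from compound 2 by 2-fluorophenyl in place of 4-fluorophenyl on a carbonyl carbon. Within the data shown here, the one measured single change, a number 37.1 percentage points higher from compound 1 to compound 2 (beyond the scatter), was large, but it swapped both the halogen and where it sits on that ring, so it bears only loosely on moving a fluorine alone. Among the measured compounds shown here, no measured pair shows such a move. The step from compound 2 to compound 4 in this assay is therefore expected to be a number 9.1 percentage points lower from compound 2 to compound 4 (within the scatter), centred near no change beyond the scatter but with wide uncertainty. Compound 4 is estimated at 42%, between 15% and 68%.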

Compound 4, a percentage reported as inhibition, in the whole organism at one dose (the size of the read-out at that dose, not a potency): 51.3%
Estimate against measurement, compound 4: 9.3 percentage points below, and the stated range covers the measured number.
By their numbers in this assay, from the lowest: compound 1; then compounds 2 and 4 (each within the scatter of the next); then compound 3.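

In this assay, moving the fluorine alone, with 2-fluorophenyl in place of 4-fluorophenyl on the carbonyl carbon, gives a step too small to read (a number 0.2 percentage points higher from compound 2 to compound 4 (within the scatter)). Set against the 3-bromophenyl group, the 2-fluorophenyl group gives a large step (a number 37.3 percentage points higher from compound 1 to compound 4 (beyond the scatter)), so the large step first seen with the 4-fluorophenyl group (a number 37.1 percentage points higher from compound 1 to compound 2 (beyond the scatter)) also appears with this isomer. Nothing on hand explains why these results fall as they do.

The compounds shown leave open how 3-fluorophenyl or 4-bromophenyl would read on that carbonyl carbon, which would separate the halogen from its place on the ring. As far as these compounds go, an amine or a carboxylic acid on that ring also remains open.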